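Swapping the free pyrazole of compound 1 for a methylated one

The source may hold more compounds than are shown below. What is called first, only, known or untested is meant among the compounds shown, and "the series" means these compounds.

Going by the values given here, compound 1 `c1cc(-c2cn[nH]c2)c2c(c1)C(c1ncc[nH]1)CC2` is the only measured compound to give a number in a functional assay on CHO cells for agonist activity at Alpha-1D adrenergic receptor (Homo sapiens), read by FLIPR and calcium flux; on this read-out higher numbers stand for an effect only at larger amounts of compound and lower numbers for an effect already at smaller amounts: compound 1 gives 319 nM. Compound 2 `Cc1c(OCC2=NCCN2)ccc(Cl)c1NS(C)(=O)=O` reaches only a limit of the assay, giving > 10000 nM in this assay. Compound 3 `Clc1ccc2c(c1-c1cn[nH]c1)CCC2c1ncc[nH]1` likewise stops at a limit, with > 10000 nM in this assay. Two of the three results thus sit at the limit of > 10000 nM in this assay, at which 2 of the 3 values shown sit. Among the compounds with values here, the single measured step, an at least 31-fold higher number from compound 1 to compound 3 (1.49 log units; beyond the scatter), concerns a different change and so does not bear on compound 4 `Cn1nccc1-c1cccc2c1CCC2c1ncc[nH]1`, whose change is 1-methyl-1H-pyrazol-5-yl in place of 1H-pyrazol-4-yl on an aromatic carbon. Within the data shown here, no measured step addresses this change, so the expectation rests on compound 1 alone. The estimate for compound 4 in this assay is 1000 nM, expected between 200 nM and 8000 nM. The expected step is a 3.1-fold higher number from compound 1 to compound 4 (0.50 log units; beyond the scatter).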

Compound 4, half-maximal effective concentration: > 10000 nM
Compound 4: no number, only a limit; the forecaster's own chance of this, stated with the estimate: 35%; middle value at least 10-fold (1.00 log units) away from the limit.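

Until now the 1H-pyrazol-4-yl of compound 1 had stayed untouched, and replacing it with 1-methyl-1H-pyrazol-5-yl on the same aromatic carbon gives an at least 31-fold higher number from compound 1 to compound 4 (1.49 log units; beyond the scatter). The result for compound 4 in this assay is a limit and not a number, so this step sets only a lower bound on the change. Compound 1 remains the only compound with a number, and the other compounds all stop at one limit: the limit of > 10000 nM in this assay, at which 3 of the 4 values shown sit.

On these data alone, whether the methyl or the changed attachment of the ring carries the step stays open. So does how 1-methyl-1H-pyrazol-4-yl or an amine on this aromatic carbon would read.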